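This account rests on a few compounds, and the source may have more. Where it says the series, first, only, none or still open, it means among the compounds named here.

Compound 1 `O=C(CN(C(=O)c1ccc(-n2ccnc2)cc1)C1CCCCC1)Nc1cc(F)cc(F)c1`: 6.1 mL.min-1.g-1
Compound 2 `O=C(CN(C(=O)c1ccc(-c2ccccn2)cc1)C1CCOCC1)Nc1cc(F)cc(F)c1`: < 0.5 mL.min-1.g-1

In an in vitro ADME assay on microsomes (Homo sapiens) for metabolic stability (a higher number here means faster removal of the compound, a lower number slower removal), compound 2 stands at < 0.5 mL.min-1.g-1, which is a limit of the assay and not a number. Compound 3 `O=C(CN(C(=O)c1ccc(-c2ccccn2)cc1)C1CCOC1)Nc1cc(F)cc(F)c1` carries oxolan-3-yl in place of oxan-4-yl on an amide-type nitrogen. For the measured compounds named here, no measured pair isolates this change. The expected step in this assay, an at least 1.2-fold higher number from compound 2 to compound 3 (0.07 log units; that floor lies within the scatter), stays within the scatter, with a small rise as the likelier direction if any shows. For compound 3 the estimate is 0.6 mL.min-1.g-1, with an expected range of 0.3 mL.min-1.g-1 to 1.5 mL.min-1.g-1.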

Compound 3, intrinsic clearance in microsomes: 3.9 mL.min-1.g-1
Compound 3: the middle estimate sits 6.5-fold (0.81 log units) below what was measured, outside the stated range (above it).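

Oxolan-3-yl in place of oxan-4-yl on an amide-type nitrogen gives an at least 7.8-fold higher number from compound 2 to compound 3 (0.89 log units; beyond the scatter) in this assay and is the first change in the series that can be read at one place. The group on this nitrogen is therefore not neutral for this read-out, at least in these compounds. Only a floor for the step can be read, because compound 2 stands at a limit of the assay and not a number: the limit of < 0.5 mL.min-1.g-1 in this assay, at which 1 of the 3 values shown sits.

From the compounds shown here alone, whether the step follows ring size or the place of the ring oxygen stays open. So does where cyclopentyl or oxetan-3-yl on the same nitrogen would fall relative to compound 2 and compound 3.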